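Sulfonyl swap on two amide cores, cytotoxicity working notes

A few compounds are considered here, and "the series" means these few. Any claim that something is new, unique, unknown or untested is made for them only; others in the source may bear on it.

Compound 1 `CCS(=O)(=O)Nc1ccc(NC(=O)c2ccc(Cl)cc2)cc1Cl` and compound 3 `O=C(Nc1ccc(NS(=O)(=O)C(F)(F)F)c(Cl)c1)c1ccc(Cl)cc1` share one core; compound 2 `CCS(=O)(=O)Nc1ccc(NC(=O)c2cccc(C(F)(F)F)c2)cc1Cl` and compound 4 `O=C(Nc1ccc(NS(=O)(=O)C(F)(F)F)c(Cl)c1)c1cccc(C(F)(F)F)c1` share another. The difference between the two cores is not broken down here.

In an ADME assay on HEK293 cells (Homo sapiens) for cytotoxicity, read by MTT assay, with a stated time of 48 h (a higher number here means a weaker inhibitor, a lower number a stronger inhibitor), compound 1 reaches only a limit, > 250000 nM, which is the limit of > 250000 nM in this assay, at which 1 of the 3 values shown sits. Compound 3 gives 191000 nM in this assay. The change between them is trifluoromethyl in place of ethyl on a sulfonyl sulfur and the step it made is an at least 1.3-fold lower number from compound 1 to compound 3 (0.11 log units; that floor lies within the scatter).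

Compound 2 gives 159000 nM in this assay; set against compound 3 this sits within the scatter. The same change is now made on the second core: trifluoromethyl in place of ethyl on a sulfonyl sulfur. Its place reads the same in both cases, so the change is taken as the same.

For compound 4 the expected step in this assay is a 1.3-fold lower number from compound 2 to compound 4 (0.10 log units; within the scatter), resting on compound 2 at 159000 nM and on the measured step of an at least 1.3-fold lower number from compound 1 to compound 3 (0.11 log units; that floor lies within the scatter). Compound 4 is therefore estimated at 125000 nM in this assay, with a range from 60000 nM to 250000 nM.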

Compound 4, half-maximal inhibitory concentration: 210000 nM
Compound 4: the middle estimate sits 1.7-fold (0.23 log units) below what was measured, within the range that was stated.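

In this assay, trifluoromethyl in place of ethyl on a sulfonyl sulfur gives a 1.3-fold higher number from compound 2 to compound 4 (0.12 log units; within the scatter), so on the second core the change leaves no readable difference in this assay. Beside the first core, the two steps can be called neither the same nor different, and this pair gives no firm evidence that the change carries, or fails to carry, from one core to the other: the same change on two cores in this assay, an at least 1.3-fold lower number (0.11 log units; that floor lies within the scatter) from compound 1 to compound 3 and a 1.3-fold higher number (0.12 log units; within the scatter) from compound 2 to compound 4; the limit leaves it open whether they differ. Compound 1 stands at a limit, not a number, so the step on the first core has only a floor: the limit of > 250000 nM in this assay, at which 1 of the 4 values shown sits.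

The compounds shown leave open how a longer chain such as propyl, an amine or a phenyl ring on the sulfonyl sulfur would read in this assay. They also leave open whether the same change would read alike on any core beyond these two.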